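The source may report more compounds than this note shows. Statements on the series, on what has been measured and on what is new or still open speak of the compounds shown alone.

Two compounds share one core and differ only in the five-membered aromatic ring on one aromatic carbon. Compound 1 `Cc1ccsc1-c1ncnc2c1ncn2C1O[C@H](CO)[C@@H](O)[C@H]1O` gives 2500 nM in a functional assay on CCRF-CEM cells (Homo sapiens) for inhibition; on this read-out lower numbers stand for stronger inhibition and higher numbers for weaker inhibition. Compound 2 `OC[C@H]1OC(n2cnc3c(-c4cc[nH]n4)ncnc32)[C@H](O)[C@@H]1O` gives 750 nM in this assay, the lowest number of the two, with compound 1 nearest. Among the measured compounds shown here, the one measured step is a 3.3-fold lower number from compound 1 to compound 2 (0.52 log units; beyond the scatter). Compound 3 `OC[C@H]1OC(n2cnc3c(-c4ccco4)ncnc32)[C@H](O)[C@@H]1O` is not yet measured; it carries furan-2-yl in place of 1H-pyrazol-3-yl on an aromatic carbon. The entering group, like that of compound 1, brings no hydrogen-bond donor, so the step of a 3.3-fold lower number from compound 1 to compound 2 (0.52 log units; beyond the scatter) suggests a higher number. The estimated step is a 2.0-fold higher number from compound 2 to compound 3 (0.30 log units; within the scatter). Compound 3 is expected to give about 1500 nM, within 500 nM to 5000 nM.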

Compound 3, half-maximal inhibitory concentration: 600 nM
The estimate for compound 3 lay 2.5-fold (0.40 log units) above the measured number; the measured number falls inside the stated range.
By their numbers in this assay, from the lowest: compounds 3 and 2 (each within the scatter of the next); then compound 1.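

In this assay the exchange of 1H-pyrazol-3-yl for furan-2-yl gives a 1.3-fold lower number from compound 2 to compound 3 (0.10 log units; within the scatter) and so removes the hydrogen-bond donor at this aromatic carbon without a change beyond the scatter. Compound 1 also has no such donor, yet furan-2-yl in place of 3-methylthiophen-2-yl gives a 4.2-fold lower number from compound 1 to compound 3 (0.62 log units; beyond the scatter) and so donor count alone does not separate these three compounds. Nothing available explains this difference. Still open, going by these compounds, is whether the methyl or the sulfur of compound 1 accounts for its higher number. On these data alone, how an amine or a phenyl ring would read at this carbon also remains open.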